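Exchanging the carbonyl substituent: working notes on compound 3

A few compounds are considered here, and "the series" means these few. Any claim that something is new, unique, unknown or untested is made for them only; others in the source may bear on it.

In an ADME assay on microsomes from liver (Homo sapiens) for metabolic stability, with a stated time of 10 min (on this read-out higher numbers stand for a more stable compound and lower numbers for a less stable compound), compound 1 (`CC(=O)N1CCC(O)(C(=O)N2CC[C@](c3ccc(C(OCc4c(F)cccc4F)(C(F)(F)F)C(F)(F)F)cc3)(S(=O)(=O)c3ccc(F)cc3)C2)CC1`) gives 16% and compound 2 (`O=C(C1CCOCC1)N1CC[C@](c2ccc(C(OCc3c(F)cccc3F)(C(F)(F)F)C(F)(F)F)cc2)(S(=O)(=O)c2ccc(F)cc2)C1`) gives 11%. Among the compounds with values here, these two values lie within the scatter of each other, so compound 2 cannot be separated from the only other measured member of the series.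

The next structure is compound 3 (`CC(=O)N1CCN(C(=O)N2CC[C@](c3ccc(C(OCc4c(F)cccc4F)(C(F)(F)F)C(F)(F)F)cc3)(S(=O)(=O)c3ccc(F)cc3)C2)CC1`), with the change (4-acetylpiperazin-1-yl in place of oxan-4-yl on a carbonyl carbon). In words, 4-acetylpiperazin-1-yl stands in place of oxan-4-yl on a carbonyl carbon, and the rest of the structure is shared.

Within the data shown here, one measured step bears on this change: a number 5 percentage points lower from compound 1 to compound 2 (within the scatter). It also exchanges the group on a carbonyl carbon, with oxan-4-yl in place of 1-acetyl-4-hydroxypiperidin-4-yl. Among the measured compounds shown here, no measured compound carries the 4-acetylpiperazin-1-yl group, so the evidence is indirect and rests on this single step.

No step beyond the scatter is therefore expected in this assay, and the estimated step is a number 4 percentage points higher from compound 2 to compound 3 (within the scatter). The range stays wide on the upper side, as one step gives little guidance. The expected value for compound 3 is 15%, with an estimated range of 5% to 32%.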

Compound 3, percent of the compound remaining: 5%
For compound 3 the middle estimate is 10 percentage points above the measured one; low and high end bracket the measured number.
By their numbers in this assay, from the lowest: compounds 3, 2 and 1 (each within the scatter of the next, the first and the last beyond it).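

In this assay, the exchange at this position now gives its first separation beyond the scatter: a number 11 percentage points lower from compound 1 to compound 3 (beyond the scatter), a modest step in which 4-acetylpiperazin-1-yl stands in place of 1-acetyl-4-hydroxypiperidin-4-yl on a carbonyl carbon. Set against oxan-4-yl, the same group does not separate, with a number 6 percentage points lower from compound 2 to compound 3 (within the scatter), so compound 2 and compound 3 cannot be told apart in this read-out, and compound 2 cannot be told apart from compound 1 either; the carbonyl substituent therefore matters only across the full span of these three compounds, not at each single exchange. Nothing available explains the separation between compound 1 and compound 3.

Because each exchange replaces a whole group, the step from compound 1 to compound 3 does not show whether the ring hydroxyl, the ring nitrogen on the carbonyl or the ring as a whole carries the difference. Still open, on these data alone, is how this position responds to a piperazin-1-yl group without the acetyl, a carboxylic acid or a longer alkyl chain on the same carbonyl carbon.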